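The source may report more compounds than this note shows. Statements on the series, on what has been measured and on what is new or still open speak of the compounds shown alone.

In an in vivo ADME assay on the whole organism for metabolic stability, with Rattus norvegicus as the target (a higher number here means that the compound lasts longer, a lower number that the compound disappears faster), compound 1 (`Cc1cc(CN2C(=O)C(C3=NS(=O)(=O)c4c(CNS(C)(=O)=O)cccc43)=C(O)[C@@H]2C(C)(C)C)ccc1F`) gives 4.18 h and compound 2 (`Cc1cc(CN2C(=O)C(C3=NS(=O)(=O)c4c(CNS(N)(=O)=O)cccc43)=C(O)[C@@H]2C(C)(C)C)ccc1F`) gives 4.7 h, so compound 2 stands level with compound 1 within the scatter. Compound 3 (`Cc1cc(CN2C(=O)C(C3=NS(=O)(=O)c4c(CN(C)S(C)(=O)=O)cccc43)=C(O)[C@@H]2C(C)(C)C)ccc1F`) carries a new group on the saturated chain carbon bound to an aromatic carbon: methyl(methylsulfonyl)amino in place of sulfamoylamino on a saturated chain carbon bound to an aromatic carbon. Among the measured compounds shown here, the only measured step nearby is a 1.1-fold higher number from compound 1 to compound 2 (0.05 log units; within the scatter), a swap of amino in place of methyl on a sulfonyl sulfur. For the measured compounds named here, no measured compound carries methyl(methylsulfonyl)amino, so no shift beyond the scatter is expected. The expected step is a 1.2-fold lower number from compound 2 to compound 3 (0.09 log units; within the scatter). For compound 3, the estimated half-life is 3.8 h, with an expected range of 1.9 h to 7 h.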

Compound 3, half-life: 3.37 h
The estimate for compound 3 lay 1.1-fold (0.05 log units) above the measured number, and the stated range covers the measured number.
By their numbers in this assay, from the lowest: compounds 3, 1 and 2 (each within the scatter of the next).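

In this assay, methyl in place of hydrogen on the sulfonamide nitrogen gives a 1.2-fold lower number from compound 1 to compound 3 (0.09 log units; within the scatter), and the swap from sulfamoylamino to methyl(methylsulfonyl)amino gives a 1.4-fold lower number from compound 2 to compound 3 (0.14 log units; within the scatter). At this place, then, a group with 0 hydrogen-bond donors and one with 2 give half-lives within the scatter of each other. Nothing available explains why these steps are so small. On these data alone, whether an amine or a carboxylic acid on the same saturated chain carbon, or a longer chain on the sulfonyl sulfur, would move the half-life beyond the scatter remains open.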